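Chloro for fluoro on a second indole core

The source may hold more compounds than are shown below. What is called first, only, known or untested is meant among the compounds shown, and "the series" means these compounds.

Compound 1 `COc1ccc2c(Cn3ccnc3)c(-c3ccc(F)cc3)[nH]c2c1` is measured in an assay on isolated protein for inhibition of Aromatase (Homo sapiens), read by ELISA, using NADPH, with a stated time of 24 h (a lower number here means a stronger inhibitor, a higher number a weaker inhibitor), at 109 nM and serves as the reference pair with compound 2 `COc1ccc2c(Cn3ccnc3)c(-c3ccc(Cl)cc3)[nH]c2c1`, which in this assay gives 1060 nM. The change between them, (chloro in place of fluoro on an aromatic carbon), produced a 9.7-fold higher number from compound 1 to compound 2 (0.99 log units; beyond the scatter). Compound 3 `Fc1ccc(-c2[nH]c3cc(F)ccc3c2Cn2cncn2)cc1` stands on a different core; how its core differs from that of compound 1 is not broken down here. In this assay compound 3 gives 54.4 nM, which lies within the scatter of compound 1 and beyond the scatter of compound 2. Compound 4 `Fc1ccc2c(Cn3cncn3)c(-c3ccc(Cl)cc3)[nH]c2c1` is not yet measured; it differs from compound 3 by chloro in place of fluoro on an aromatic carbon, the same change as from compound 1 to compound 2, at the same place. The expectation is that compound 4 weakens in the same direction, with an estimated 7.4-fold higher number from compound 3 to compound 4 (0.87 log units; beyond the scatter), somewhat tempered toward the middle since this change is seen only once and in this assay compound 1 gave 109 nM on another core. Compound 4 is estimated at 400 nM, with an expected span from 130 nM to 1300 nM.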

Compound 4, half-maximal inhibitory concentration: 217 nM
For compound 4 the middle estimate is 1.8-fold (0.27 log units) above the measured one; measured number inside the range.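

In this assay the change from 4-fluorophenyl to 4-chlorophenyl again gives a weaker inhibitor on the second core, with a 4.0-fold higher number from compound 3 to compound 4 (0.60 log units; beyond the scatter). The direction therefore holds on both cores shown, and the size of the step does not separate them: the same change on two cores in this assay, a 9.7-fold higher number (0.99 log units; beyond the scatter) from compound 1 to compound 2 and a 4.0-fold higher number (0.60 log units; beyond the scatter) from compound 3 to compound 4, 2.4-fold (0.39 log units) apart, within the scatter of two such steps. This rests on two pairs in a single assay, so it supports carrying the change between these two cores only; it does not establish that the step would hold on a further core, and it says nothing about how the two cores themselves compare, as these pairs do not break that difference down.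

Still open, from the compounds shown here alone, is how other groups at this place on the aromatic ring would read on either core, for example bromo, methyl, a nitrile or a carboxylic acid. Also open, going by these compounds, is whether fluoro and chloro would keep this order with an amine or a longer chain elsewhere on the core.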